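A few compounds are considered here, and "the series" means these few. Any claim that something is new, unique, unknown or untested is made for them only; others in the source may bear on it.

The measured compounds are these:
compound 1 `O=C(NN=C(c1ccccn1)c1ccccn1)c1ccc([N+](=O)[O-])cc1` gives 260 nM in an ADME assay on cells (Homo sapiens) for antiproliferative activity, read by MTT assay; on this read-out higher numbers stand for weaker inhibition and lower numbers for stronger inhibition;
compound 3 `O=C(NN=C(c1ccccn1)c1ccccn1)c1ccc(O)cc1` gives 7530 nM in this assay;
compound 2 `C/C(=N\NC(=O)c1ccc(O)cc1)c1cnccn1` gives 16800 nM in this assay.

Among the measured compounds shown here, compounds 1 and 3 share one core, and between them the single change is nitro in place of hydroxy on an aromatic carbon. That change brought a 29-fold lower number from compound 3 to compound 1 (1.46 log units; beyond the scatter). Compound 2 is built on a different core; the difference between the two cores is not broken down here, but compound 2 gives the highest number of the three, standing beyond the scatter from compound 3 and far beyond it from compound 1.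

Compound 4 `C/C(=N\NC(=O)c1ccc([N+](=O)[O-])cc1)c1cnccn1`, not yet measured, is compound 2 with the same change, (nitro in place of hydroxy on an aromatic carbon), set at the same kind of place. Because the step of a 29-fold lower number from compound 3 to compound 1 (1.46 log units; beyond the scatter) was large and the change is the same, compound 4 is expected to sit well below compound 2 in this assay, though with a different core the step may not carry over in full. The expected step is a 21-fold lower number from compound 2 to compound 4 (1.32 log units; beyond the scatter). The estimate for compound 4 in this assay is 800 nM, with a range from 250 nM to 3000 nM.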

Compound 4, half-maximal inhibitory concentration in the Homo sapiens assay: 1390 nM
Estimate against measurement, compound 4: 1.7-fold (0.24 log units) below, within the range that was stated.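

In the Homo sapiens assay compound 4 gives 1390 nM. In the Homo sapiens assay, nitro in place of hydroxy gave a 12-fold lower number from compound 2 to compound 4 (1.08 log units; beyond the scatter), a large step in the same direction as the one seen on the other core. Set side by side, the two steps do not differ beyond what repeated measurements would allow: the same change on two cores in the Homo sapiens assay, a 29-fold lower number (1.46 log units; beyond the scatter) from compound 3 to compound 1 and a 12-fold lower number (1.08 log units; beyond the scatter) from compound 2 to compound 4, 2.4-fold (0.38 log units) apart, within the scatter of two such steps. This shows that the change carried over between these two cores in direction and, within the scatter, in size, but it rests on a single pair of cores and does not show why the change acts as it does or that it would hold on a third core, and in a physicochemical assay for lipophilicity (on this read-out higher numbers stand for higher lipophilicity and lower numbers for lower lipophilicity), the same change gave only a number 0.20 log units higher from compound 2 to compound 4 (within the scatter). In the physicochemical assay compound 2 gives 1.9 and compound 4 gives 2.1.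

The compounds shown carry only hydroxy or nitro at this place, so it remains open whether an amine, a carboxylic acid or a chlorine atom there would follow the same course on either core. Also open is what the difference between the two cores contributes by itself, as no pair shown isolates it.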